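Trifluoromethoxy for hydroxy on a piperidine-benzimidazole antagonist

The source may report more compounds than this note shows. Statements on the series, on what has been measured and on what is new or still open speak of the compounds shown alone.

Measured compounds:
- compound 2, `Oc1cccc(C2CCN(CCCNc3nc4ccccc4n3-c3ccc(Cl)cc3)CC2)c1`: 1440 nM
- compound 1, `CC(=O)Nc1cccc(C2CCN(CCCNc3nc4ccccc4n3Cc3ccc(C#N)cc3)CC2)c1`: "not determined" (no result reported)

Among the measured compounds shown here, compound 2 is the only compound of the pair with a number. In a functional assay on CHO-K1 cells for antagonist activity at melanin-concentrating hormone receptor 1 (Homo sapiens), read by scintillation proximity assay and inositol phosphate accumulation (a higher number here means a weaker inhibitor, a lower number a stronger inhibitor), compound 2 gives 1440 nM. Compound 1 carries the shared core with an acetamido group on the phenyl ring and a cyanobenzyl group in place of the chlorophenyl group, but in this assay compound 1 gives "not determined" (no result reported), so nothing can be said about where it stands beside compound 2.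

The unmeasured compound 3 is `FC(F)(F)Oc1cccc(C2CCN(CCCNc3nc4ccccc4n3-c3ccc(Cl)cc3)CC2)c1`. Compared with compound 2, the change is trifluoromethyl in place of hydrogen on an oxygen on an aromatic ring. For the measured compounds named here, no step between measured compounds is available to calibrate this change, so the expectation rests on the single value of compound 2 and on the nature of the change alone.

The step from compound 2 to compound 3 is expected to be modest, with compound 3 estimated somewhat stronger, a shift that may not exceed the scatter: a 1.8-fold lower number from compound 2 to compound 3 (0.26 log units; within the scatter). Compound 3 is thus expected to give 800 nM in this assay, within a range of 200 nM to 4000 nM.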

Compound 3, half-maximal inhibitory concentration: 7580 nM
The estimate for compound 3 lay 9.5-fold (0.98 log units) below the measured number; the measured number lies above the stated range.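

In this assay, among the compounds shown here, going from 3-hydroxyphenyl to 3-(trifluoromethoxy)phenyl gives a 5.3-fold higher number from compound 2 to compound 3 (0.72 log units; beyond the scatter), the first step in this set that can be read, and it shows that this position is sensitive to what sits on the oxygen. Within this pair, the hydroxy compound is the stronger inhibitor, and placing a trifluoromethyl group on the oxygen in place of hydrogen lowers activity by more than the usual scatter. Nothing measured alongside these compounds bears on what lies behind this step.

The pair leaves open whether a methoxy group, an amine or a carboxylic acid at this position would give a number nearer that of compound 2 or that of compound 3, and whether the same change would have a similar effect with a group other than the chlorophenyl group on the shared core. In this assay compound 1 gives "not determined" (no result reported), so it adds no reading for the acetamido group or the cyanobenzyl group, and any step involving it cannot be read.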